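The source may hold more compounds than are shown below. What is called first, only, known or untested is meant among the compounds shown, and "the series" means these compounds.

In a functional assay on U-937 cells (Homo sapiens) for cytotoxicity, read by MTT assay, with a stated time of 48 h (a lower number here means a stronger inhibitor, a higher number a weaker inhibitor), compound 1 `Fc1cccc(-c2nc(Nc3ccccc3)c3ccccc3n2)c1` gives > 50000 nM, which is a limit of the assay and not a number. Compound 2 `Fc1cccc(Nc2nc(-c3cccc(F)c3)nc3ccc(F)cc23)c1` gives a true reading of 42300 nM. Compound 3 `Fc1cccc(-c2nc(Nc3ccccc3Cl)c3cc(F)ccc3n2)c1` gives > 50000 nM, again only a limit, so its position is known only as a bound. The overall picture is the limit of > 50000 nM in this assay, at which 2 of the 3 values shown sit.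

Compound 4 `Nc1ccc(Nc2nc(-c3cccc(F)c3)nc3ccc(F)cc23)cc1` differs from compound 3 at one place: 4-aminophenyl in place of 2-chlorophenyl on a nitrogen on an aromatic ring. The change is 4-aminophenyl in place of 2-chlorophenyl on a nitrogen on an aromatic ring. Among the measured compounds shown here, only one measured step bears on this place: an at least 1.1-fold higher number from compound 2 to compound 3 (0.07 log units; that floor lies within the scatter). Its floor lies within the scatter, so it gives no sign that changing this group moves the reading far. For the measured compounds named here, the one true number in the set is that of compound 2 at 42300 nM, so a reading in that neighbourhood is expected. Compound 4 may instead give another limit. The expected move is small and towards a lower number: an at least 1.6-fold lower number from compound 3 to compound 4 (0.22 log units; that floor lies within the scatter). For compound 4 the estimate is 30000 nM, with an expected range from 12000 nM to 50000 nM.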

Compound 4, half-maximal inhibitory concentration: > 50000 nM
Compound 4: no number, only a limit (the forecaster's own chance of this, stated with the estimate: 45%); middle value at least 1.6-fold (0.22 log units) away from the limit.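

In this assay compound 4 gives only a limit, so the change from 2-chlorophenyl to 4-aminophenyl cannot be sized, and the step between compound 3 and compound 4, both limits, cannot be read. Among the compounds shown here, measured against the one true number in the set, the change to 4-aminophenyl gives an at least 1.1-fold higher number from compound 2 to compound 4 (0.07 log units; that floor lies within the scatter). A group with a hydrogen-bond donor and a hydrogen-bond acceptor, on a nitrogen on an aromatic ring, therefore adds compound 4 to the compounds without a true reading, and the set now shows: the limit of > 50000 nM in this assay, at which 3 of the 4 values shown sit.

Going by these compounds, how compound 3 and compound 4 rank against each other stays open. Also open, on these data alone, is whether a carboxylic acid or a longer chain on this phenyl ring would bring a reading clearly lower than that of compound 2.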